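Rat clearance notes on an acrylamide urea series

A few compounds are considered here, and "the series" means these few. Any claim that something is new, unique, unknown or untested is made for them only; others in the source may bear on it.

Values in an ADME assay on the whole organism (strain Sprague-Dawley) for pharmacokinetics, with Rattus norvegicus as the target, read by LC-MS, at a dose of 5 mg/kg by the intravenous route (on this read-out lower numbers stand for slow clearance and higher numbers for fast clearance), so far:
- compound 1 `C=CC(=O)N1CC[C@H](N2C(=O)N(c3ccccc3)Cc3cnc(Nc4cccc(N5CCN(C)CC5)c4)nc32)C1`: 113 mL/min/kg
- compound 2 `C=CC(=O)N1CC[C@H](N2C(=O)N(c3ccccc3)Cc3cnc(Nc4ccc(N5CCN(C)CC5)cc4)nc32)C1`: 96.7 mL/min/kg
- compound 3 `C=CC(=O)N1CC[C@H](N2C(=O)N(c3ccccc3)Cc3cnc(Nc4ccc(N5CCN(C)CC5)c(C)c4)nc32)C1`: 51.7 mL/min/kg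

Compound 2 sits between the other two numbers: compound 1 is its nearest neighbour, within the scatter, and compound 3 its furthest, with a 1.9-fold lower number from compound 2 to compound 3 (0.27 log units; within the scatter), also within the scatter. None of the three compounds separates from the others beyond repeat-measurement noise, and all three numbers sit at the fast end of the read-out.

Compound 4 `C=CC(=O)N1CC[C@H](N2C(=O)N(c3ccccc3)Cc3cnc(Nc4ccccc4)nc32)C1` is the next entry. Relative to compound 2 the change is hydrogen in place of 4-methylpiperazin-1-yl on an aromatic carbon. Going by the values given here, no measured step bears on this change: the only step in hand, from compound 2 to compound 3, concerns a methyl group elsewhere on the same ring and stayed within the scatter. With nothing in the series pointing either way, the expectation for compound 4 in this assay is a number close to that of compound 2, with a 1.1-fold lower number from compound 2 to compound 4 (0.06 log units; within the scatter) not expected to exceed the scatter. The estimate for compound 4 is 85 mL/min/kg, expected between 35 mL/min/kg and 170 mL/min/kg.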

Compound 4, clearance: 41.7 mL/min/kg
Estimate against measurement, compound 4: 2.0-fold (0.31 log units) above; low and high end bracket the measured number.
By their numbers in this assay, from the lowest: compounds 4, 3, 2 and 1 (each within the scatter of the next, the first and the last beyond it).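

In this assay, going by these compounds alone, this is the first exchange to step beyond the scatter: hydrogen in place of 4-methylpiperazin-1-yl on the aromatic carbon gives a 2.3-fold lower number from compound 2 to compound 4 (0.37 log units; beyond the scatter), and the same exchange from the group's other place on the ring gives a 2.7-fold lower number from compound 1 to compound 4 (0.43 log units; beyond the scatter). Both steps are modest and run the same way, so in these pairs the higher numbers go with the group, at either place, although compound 3, which keeps the group and adds a methyl, goes against any simple link at 51.7 mL/min/kg. No measurement at hand bears on why the number falls.

Still open, going by these compounds, is whether the whole ring matters or only part of it. A piperazine without its methyl, a morpholine or a small dimethylamino group on the same carbon would separate these readings.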